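A few compounds are considered here, and "the series" means these few. Any claim that something is new, unique, unknown or untested is made for them only; others in the source may bear on it.

Of the compounds shown here, three built on a shared core have been measured in an assay on Ltk cells with metabotropic glutamate receptor 5 (Homo sapiens) as the target, read by fluorescence and calcium flux; a lower number here means a stronger inhibitor, a higher number a weaker inhibitor. Compound 1 `CCOc1cccnc1Nc1cccc(C)n1` gives 40 nM. Compound 2 `CCOc1cc(C#N)cnc1Nc1cccc(C)n1` carries a cyano group where compound 1 has hydrogen on an aromatic carbon; in this assay compound 2 gives 46 nM, and the step is a 1.2-fold higher number from compound 1 to compound 2 (0.06 log units; within the scatter). Compound 3 `CCOc1cc(-c2cnccc2C)cnc1Nc1cccc(C)n1` carries a 4-methylpyridin-3-yl group on that aromatic carbon and gives 45 nM. The step is a 1.1-fold higher number from compound 1 to compound 3 (0.05 log units; within the scatter) and, from the cyano compound, a 1.0-fold lower number from compound 2 to compound 3 (0.01 log units; within the scatter). Compound 3 therefore stands second highest of the three numbers, with all three lying within the scatter of one another.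

Compound 4 `CCOc1cc(-c2cccnc2C#N)cnc1Nc1cccc(C)n1` has not yet been measured. It differs from compound 3 in one place: 2-cyanopyridin-3-yl in place of 4-methylpyridin-3-yl on an aromatic carbon. The three steps already seen all change this same aromatic carbon, and each stays within the scatter, so no step beyond the scatter is expected in this assay, in either direction. Compound 4 is estimated at 45 nM, with a range from 20 nM to 100 nM. The expected step is no change at the digits printed from compound 3 to compound 4 (within the scatter), which is expected to remain within the scatter.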

Compound 4, half-maximal inhibitory concentration: 80 nM
Estimate against measurement, compound 4: 1.8-fold (0.25 log units) below; low and high end bracket the measured number.
By their numbers in this assay, from the lowest: compounds 1, 3, 2 and 4 (each within the scatter of the next).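

In this assay, this aromatic carbon, para to the (6-methylpyridin-2-yl)amino group, now also carries a 2-cyanopyridin-3-yl group, and the three new steps are larger than the earlier ones at this position, though each is printed as within the scatter (a 1.8-fold higher number from compound 3 to compound 4 (0.25 log units; within the scatter); a 1.7-fold higher number from compound 2 to compound 4 (0.24 log units; within the scatter); a 2.0-fold higher number from compound 1 to compound 4 (0.30 log units; within the scatter)). So hydrogen, cyano and both substituted pyridines can all sit here without any step beyond the scatter, even when the 4-methylpyridin-3-yl group gives way to one with a triple bond and 2 hydrogen-bond acceptors. No measurement is available that explains these numbers.

What the compounds shown leave open is whether any group at this carbon gives a step beyond the scatter. An amine, a carboxylic acid or a longer chain such as butoxy might do so, or might not.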